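A few compounds are considered here, and "the series" means these few. Any claim that something is new, unique, unknown or untested is made for them only; others in the source may bear on it.

Measured in an assay on isolated protein for inhibition of DNA topoisomerase 1 (Homo sapiens), with a stated time of 30 min, tested at 100 uM; on this read-out higher numbers stand for a stronger effect at the one concentration tested and lower numbers for a weaker effect:

Compound 1, `Oc1ccc(-c2cc(-c3ccccc3)nc(-c3ccccc3Cl)c2)cc1`: 13.6%
Compound 2, `Oc1ccc(-c2cc(-c3ccco3)nc(-c3ccccc3Cl)c2)cc1`: 3.9%
Compound 3, `Oc1ccc(-c2cc(-c3cccc(Cl)c3)nc(-c3ccco3)c2)cc1`: 25.5%

Compound 4, `Oc1ccc(-c2cc(-c3ccccc3)nc(-c3cccc(Cl)c3)c2)cc1`, has not yet been measured. It arises from compound 3 by the change (phenyl in place of furan-2-yl on an aromatic carbon). The same kind of change, (phenyl in place of furan-2-yl on an aromatic carbon), has been made once already, from compound 2 to compound 1, where it gave a number 9.7 percentage points higher from compound 2 to compound 1 (within the scatter). The two cores are not the same: compound 3 differs from compound 2 by 3-chlorophenyl in place of 2-chlorophenyl on an aromatic carbon, which gave a number 21.6 percentage points higher from compound 2 to compound 3 (beyond the scatter) in this assay. Around the place of the change, compound 1 has the phenyl meta to a 2-chlorophenyl group, whereas compound 4 has it meta to a 3-chlorophenyl group, so the change is of the same kind, not the same.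

Because the earlier step of a number 9.7 percentage points higher from compound 2 to compound 1 (within the scatter) lay within the scatter, the step from compound 3 to compound 4 is expected to be small as well, about a number 5.5 percentage points higher from compound 3 to compound 4 (within the scatter). Compound 4 is therefore estimated at 31%, likely between 16% and 48%.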

Compound 4, a percentage reported as inhibition, at one concentration (the size of the read-out at that concentration, not a potency): 0%
Compound 4: the middle estimate sits 31 percentage points above what was measured; the measured number lies below the stated range.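

In this assay, phenyl in place of furan-2-yl gave a number 25.5 percentage points lower from compound 3 to compound 4 (beyond the scatter), so the step seen on one core did not carry over to the other: the same change on two cores in this assay, a number 9.7 percentage points higher (within the scatter) from compound 2 to compound 1 and a number 25.5 percentage points lower (beyond the scatter) from compound 3 to compound 4, 35.2 percentage points apart, beyond the scatter of two such steps

Seen from the other side, 3-chlorophenyl in place of 2-chlorophenyl gave a number 13.6 percentage points lower from compound 1 to compound 4 (beyond the scatter), and this step also depends on its core: the same change on two cores in this assay, a number 21.6 percentage points higher (beyond the scatter) from compound 2 to compound 3 and a number 13.6 percentage points lower (beyond the scatter) from compound 1 to compound 4, 35.2 percentage points apart, beyond the scatter of two such steps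

So in these four compounds the effects of the two changes do not simply add up, but the numbers do not show why, and two cores give no rule for any further core.

Still open, as far as these compounds go, is how the phenyl and furan-2-yl groups would compare if an amine or a carboxylic acid stood in place of the chlorine. Also open, from the compounds shown here alone, is how these compounds would rank across a range of concentrations, since each number comes from a single one.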